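Fluorophenyl for thienyl on a shared benzofuran-free core

A few compounds are considered here, and "the series" means these few. Any claim that something is new, unique, unknown or untested is made for them only; others in the source may bear on it.

Compound 1 `Cc1nc(-c2ccsc2)sc1COc1ccc2c(c1)OCC2CC(=O)O` is the reference point of this set. Among the measured compounds shown here, in a functional assay on CHO cells for agonist activity at Free fatty acid receptor 1 (Homo sapiens), read by FLIPR and calcium flux (on this read-out higher numbers stand for an effect only at larger amounts of compound and lower numbers for an effect already at smaller amounts), compound 1 gives 68.5 nM, and this is the only number the set holds: compound 2 `Cc1nc(-c2cccc3ccccc23)sc1COc1ccc2c(c1)OCC2CC(=O)O` is reported in this assay as "not determined" (no result reported), and compound 3 `Cc1ccccc1-c1nc(C)c(COc2ccc3c(c2)OCC3CC(=O)O)s1` is reported in this assay as "not determined" (no result reported), so both are present without a result and nothing can be said about how they compare with compound 1. For the measured compounds named here, no step between two measured compounds exists here.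

Compound 4 `Cc1nc(-c2ccc(F)cc2)sc1COc1ccc2c(c1)OCC2CC(=O)O` is the unmeasured member. It differs from compound 1 in a single place: 4-fluorophenyl in place of thiophen-3-yl on an aromatic carbon. The change sits on an aromatic carbon of a five-membered aromatic ring with one nitrogen and one sulfur, two ring bonds from the ring atom that bears the large group.

With only compound 1 as a foothold, the author expects compound 4 to stay close to it, with a step of a 1.4-fold lower number from compound 1 to compound 4 (0.14 log units; within the scatter) that is expected to lie within or only slightly beyond the usual scatter, if anything toward smaller amounts. Compound 4 is therefore estimated at 50 nM in this assay, with a likely range from 15 nM to 200 nM.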

Compound 4, half-maximal effective concentration: 48.7 nM
The estimate for compound 4 lay 1.0-fold (0.01 log units) above the measured number, and the stated range covers the measured number.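

In this assay, among the compounds shown here, 4-fluorophenyl in place of thiophen-3-yl gives a 1.4-fold lower number from compound 1 to compound 4 (0.15 log units; within the scatter), the first step that can be read at this aromatic carbon next to the ring nitrogen and next to the ring sulfur. At this place, therefore, a six-membered aromatic ring of carbon only can stand in for a five-membered aromatic ring with 1 hetero atom without a step beyond the scatter. No measured property of these groups is available to account for this result.

The steps to compound 2 and compound 3 cannot be read, so this single step is all that is known about the group at this position. The compounds shown leave open whether an amine or a carboxylic acid in place of the fluorine on the phenyl ring would also stay within the scatter.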